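Chloro to hydrogen: from 2-chlorophenyl to phenyl

This account rests on a few compounds, and the source may have more. Where it says the series, first, only, none or still open, it means among the compounds named here.

In a functional assay on SMMC-7721 cells (Homo sapiens) for inhibition, read by CCK-8 assay, with a stated time of 72 h (on this read-out higher numbers stand for weaker inhibition and lower numbers for stronger inhibition), compound 1 (`Nc1ccccc1NC(=O)c1ccc(CNC(=O)c2n[nH]cc2NC(=O)c2c(F)cccc2Cl)cc1`) gives 16300 nM, and compound 2 (`Nc1ccccc1NC(=O)c1ccc(CNC(=O)c2n[nH]cc2NC(=O)c2ccccc2Cl)cc1`) gives 12900 nM. Going by the values given here, these two numbers lie within the scatter of each other, so compound 2 stands level with the only other compound measured so far.

Compound 3 (`Nc1ccccc1NC(=O)c1ccc(CNC(=O)c2n[nH]cc2NC(=O)c2ccccc2)cc1`) has not yet been measured. It differs from compound 2 as follows: hydrogen in place of chloro on an aromatic carbon. This is hydrogen in place of chloro on an aromatic carbon, ortho to a large group, turning 2-chlorophenyl into phenyl.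

Among the compounds with values here, one measured step bears on this change: a 1.3-fold lower number from compound 1 to compound 2 (0.10 log units; within the scatter). It puts hydrogen in place of fluoro on an aromatic carbon and stays within the scatter. Within the data shown here, no measured step covers the loss of chloro, so the support is thin and the range is kept wide.

No change beyond the scatter is expected in this assay, and no firm direction is assumed. The estimated step is a 1.1-fold higher number from compound 2 to compound 3 (0.04 log units; within the scatter). For compound 3 the expected value is 14000 nM, with an estimated range of 6000 nM to 32000 nM.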

Compound 3, half-maximal inhibitory concentration: 6620 nM
The estimate for compound 3 lay 2.1-fold (0.33 log units) above the measured number; the measured number falls inside the stated range.
By their numbers in this assay, from the lowest: compounds 3, 2 and 1 (each within the scatter of the next, the first and the last beyond it).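

In this assay, hydrogen in place of chloro on the aromatic carbon ortho to a large group gives a 1.9-fold lower number from compound 2 to compound 3 (0.29 log units; within the scatter) and so does not, taken alone, separate these two compounds. Going by these compounds alone, the wider change, phenyl in place of 2-chloro-6-fluorophenyl on the carbonyl carbon, gives a 2.5-fold lower number from compound 1 to compound 3 (0.39 log units; beyond the scatter) and is the only step in this set beyond the scatter, though a modest one; in this short series, a difference that can be read appears only when the comparison spans the loss of both chloro and fluoro. No accompanying measurement offers an account of this difference, and the numbers alone cannot supply one.

Still open is whether this position responds more clearly to groups of another kind, such as methoxy, an amine or a carboxylic acid, since the compounds shown carry only hydrogen, fluoro and chloro on this phenyl. Also open, going by these compounds, is whether the gap between compound 1 and compound 3 would hold in other cell lines, and whether changes elsewhere on the shared core would shift these numbers further than any change on this benzoyl group does.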